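This account rests on a few compounds, and the source may have more. Where it says the series, first, only, none or still open, it means among the compounds named here.

For the measured compounds named here, in a functional assay on the whole organism for inhibition, with Homo sapiens as the target (a lower number here means a stronger inhibitor, a higher number a weaker inhibitor), compound 3 `O=C(NC[C@H](NS(=O)(=O)c1ccccc1)C(=O)O)c1cc2c(s1)CCN(CCC1CCNCC1)C2=O` gives 7 nM, the lowest of the three numbers measured so far. Compound 1 `O=C(O)CCNC(=O)c1cc2c(s1)CCN(CCC1CCNCC1)C2=O` gives 150 nM and compound 2 `O=C(O)CCCC(=O)c1cc2c(s1)CCN(CCC1CCNCC1)C2=O` gives 260 nM; between those two the step is small, a 1.7-fold higher number from compound 1 to compound 2 (0.24 log units; within the scatter). Going by the values given here, the one large step came from adding a group at the chain carbon: a 21-fold lower number from compound 1 to compound 3 (1.33 log units; beyond the scatter). Compound 4 `O=C(NCc1ccccc1)N[C@@H](CNC(=O)c1cc2c(s1)CCN(CCC1CCNCC1)C2=O)C(=O)O` alters that very group: benzylcarbamoyl in place of phenylsulfonyl on an amine nitrogen. Among the compounds with values here, no measured step compares these two groups directly, so only the step from compound 1 to compound 3 bears on the change, and it shows that what sits on this amine nitrogen can move the number a great deal. A modest weakening is expected, a 2.1-fold higher number from compound 3 to compound 4 (0.33 log units; beyond the scatter), with wide uncertainty. Compound 4 is therefore estimated at 15 nM, between 4 nM and 60 nM.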

Compound 4, half-maximal inhibitory concentration: 25 nM
For compound 4 the middle estimate is 1.7-fold (0.22 log units) below the measured one; the range from low to high includes it.
By their numbers in this assay, from the lowest: compound 3; then compound 4; then compounds 1 and 2 (each within the scatter of the next).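

In this assay, for the compounds shown here, the amine nitrogen accepts a second kind of group: benzylcarbamoyl in place of phenylsulfonyl gives a 3.6-fold higher number from compound 3 to compound 4 (0.55 log units; beyond the scatter), so phenylsulfonyl is not the only group that yields a low number here. Set against a plain hydrogen on the chain carbon, (benzylcarbamoyl)amino gives a 6.0-fold lower number from compound 1 to compound 4 (0.78 log units; beyond the scatter), a smaller gain than (phenylsulfonyl)amino gave. No measured evidence explains the difference between these two groups. The compounds shown leave open how a simple amine or an acetyl group on this nitrogen would compare, so how much of the gain depends on the aromatic ring remains unknown.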